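The source may hold more compounds than are shown below. What is called first, only, known or untested is meant among the compounds shown, and "the series" means these compounds.

Measured so far in a functional assay, with a stated time of 20 min, tested at 3 mg/mL; on this read-out higher numbers stand for a stronger effect at the one concentration tested and lower numbers for a weaker effect:
- compound 1 `CC(C)[C@@H]1CC[C@@H](C)C[C@@]12N(C)C(=O)[C@@H]1[C@H]3C(=O)NC(=O)[C@H]3ON12` gives 80.3%
- compound 2 `CC(C)[C@@H]1CC[C@@H](C)C[C@@]12N(C)C(=O)[C@@H]1[C@H]3C(=O)N(c4ccccc4)C(=O)[C@H]3ON12` gives 80.7%
- compound 3 `Cc1cccc(N2C(=O)[C@H]3[C@H](ON4[C@@H]3C(=O)N(C)[C@@]43C[C@H](C)CC[C@H]3C(C)C)C2=O)c1` gives 73.8%

Compound 3 has the lowest of the three numbers, but neither gap separates it from the others: compound 1 sits nearest to it and compound 2 furthest, and both gaps are within the scatter. The three values read as one level on this assay.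

Compound 4 `CC(C)[C@@H]1CC[C@@H](C)C[C@@]12N(C)C(=O)[C@@H]1[C@H]3C(=O)N(c4ccc5ccccc5c4)C(=O)[C@H]3ON12` differs from compound 3 only on the ring nitrogen: naphthalen-2-yl in place of 3-methylphenyl on an amide-type nitrogen in a ring.

For the measured compounds named here, the steps that bear on this change all sit on the same nitrogen. The step of a number 0.4 percentage points higher from compound 1 to compound 2 (within the scatter) adds phenyl to the bare amide hydrogen without moving the number; the step of a number 6.5 percentage points lower from compound 1 to compound 3 (within the scatter) adds 3-methylphenyl with the same outcome; and the step of a number 6.9 percentage points lower from compound 2 to compound 3 (within the scatter), a methyl on the aromatic carbon, is also flat. Every substitution tried at this position, from nothing up to a methyl-bearing phenyl, has left the read-out within scatter. Going on to a naphthalen-2-yl is a larger group than any tried, so the expectation is weaker, but nothing measured points in either direction; no step beyond the scatter is expected, a number 2.2 percentage points higher from compound 3 to compound 4 (within the scatter).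

Compound 4 is therefore estimated at 76%, with a range of 60% to 88%.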

Compound 4, a percentage reported as activity, at one concentration (the size of the read-out at that concentration, not a potency): 50.9%
Compound 4: middle estimate off by 25.1 percentage points, on the high side; the measured number lies below the stated range.
By their numbers in this assay, from the lowest: compound 4; then compounds 3, 1 and 2 (each within the scatter of the next).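

For the compounds shown here, on this assay, the amide-type nitrogen in a ring is not indifferent to its substituent: naphthalen-2-yl in place of 3-methylphenyl gives the first step beyond the scatter at this position, a number 22.9 percentage points lower from compound 3 to compound 4 (beyond the scatter). Going by these compounds alone, the same replacement is also beyond the scatter against phenyl, a number 29.8 percentage points lower from compound 2 to compound 4 (beyond the scatter), and against the amide hydrogen, a number 29.4 percentage points lower from compound 1 to compound 4 (beyond the scatter), so the read-out stays at one level across hydrogen, phenyl and 3-methylphenyl and drops only with naphthalen-2-yl, the one group here with two six-membered aromatic rings. Nothing available bears on why this group lowers the number.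

As far as these compounds go, it remains open whether the drop follows the second aromatic ring itself or the particular naphthalen-2-yl shape, a question that naphthalen-1-yl, benzyl or 4-phenylphenyl on the same nitrogen would address. From the compounds shown here alone, it is also open whether a pyridinyl ring, or a phenyl carrying an amine or a carboxylic acid, stays at the level of compound 2 or falls towards compound 4, and, with one concentration tested, whether the weaker effect seen at that concentration would also appear at other concentrations.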